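Replacing an alkyne with a pyridine on the acid side chain

The source may report more compounds than this note shows. Statements on the series, on what has been measured and on what is new or still open speak of the compounds shown alone.

Measured so far:
Compound 1 `COCCOc1ccc2c(c1)OC(COc1ccc(CCC(=O)O)c(F)c1)CC2` — 2370 nM
Compound 2 `O=C(O)CCc1ccc(OCC2COc3ccc(Br)cc3O2)cc1F` — 2240 nM
Compound 3 `CC#CC(CC(=O)O)c1ccc(OCC2COc3ccc(Cl)cc3O2)cc1` — 100 nM

Of the compounds shown here, three share a core and have been tested in a functional assay on HEK293 cells for agonist activity at Free fatty acid receptor 1 (Homo sapiens), read by fluorescence and calcium flux, with a stated time of 10 min; on this read-out higher numbers stand for an effect only at larger amounts of compound and lower numbers for an effect already at smaller amounts. In this assay compound 1 gives 2370 nM and compound 2 gives 2240 nM; these two numbers lie within the usual scatter of each other, so neither can be called stronger. Compound 3, in this assay, gives 100 nM and stands lowest of the three, with the gap to compound 2 and to compound 1 both beyond the scatter, so compound 3 is the most potent of the measured set.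

Compound 4 `O=C(O)CC(c1ccncc1)c1ccc(OCC2COc3ccc(Cl)cc3O2)cc1` has not yet been measured. It differs from compound 3 in one place: pyridin-4-yl in place of prop-1-yn-1-yl on a saturated chain carbon bound to an aromatic carbon and a saturated chain carbon. For the measured compounds named here, no measured pair in this set shows this kind of exchange, so the data give no direct guide to its size or direction. The expectation is a small loss, with the step from compound 3 to compound 4 estimated at a 2.5-fold higher number from compound 3 to compound 4 (0.40 log units; beyond the scatter), which may well stay within the scatter. On that basis compound 4 is expected to give about 250 nM, within a range from 60 nM to 1000 nM.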

Compound 4, half-maximal effective concentration: 1170 nM
Compound 4: the middle estimate sits 4.7-fold (0.67 log units) below what was measured, and the stated range ends below it.
By their numbers in this assay, from the lowest: compound 3; then compounds 4, 2 and 1 (each within the scatter of the next, the first and the last beyond it).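

In this assay, putting pyridin-4-yl in place of prop-1-yn-1-yl on a saturated chain carbon bound to an aromatic carbon and a saturated chain carbon gives a 12-fold higher number from compound 3 to compound 4 (1.07 log units; beyond the scatter), a large step. For the compounds shown here, the earlier compounds offered no pair differing at this carbon, so this is the first direct sign that the group held there strongly affects how much compound is needed for an effect. No measurement at hand explains the change, and the exchange replaces a chain with a triple bond by a six-membered aromatic ring containing nitrogen, so this single pair cannot show which difference matters.

A phenyl ring at this carbon would show whether the loss follows the ring itself or its nitrogen, while pyridin-3-yl would test whether the place of that nitrogen in the ring matters. A small cyclopropyl group or a plain ethynyl group would show whether the triple bond of prop-1-yn-1-yl is needed, or whether other compact groups can stand in its place.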